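Amide aryl variation across a weakly inhibitory series

The source may hold more compounds than are shown below. What is called first, only, known or untested is meant among the compounds shown, and "the series" means these compounds.

Compound 1 `O=C(Cn1c(=O)c(/C=C\c2ccncc2)nc2ccccc21)Nc1ccc(F)cc1` in a functional assay on PC-3 cells (Homo sapiens) for inhibition, read by MTT assay, with a stated time of 24 h; on this read-out higher numbers stand for weaker inhibition and lower numbers for stronger inhibition: 59900 nM
Compound 2 `O=C(Cn1c(=O)c(/C=C\c2ccncc2)nc2ccccc21)Nc1ccc(Cl)cc1`, a limit only: > 100000 nM
Compound 3 `O=C(Cn1c(=O)c(/C=C\c2ccncc2)nc2ccccc21)Nc1ccc(Cl)c(Cl)c1`, a limit only: > 100000 nM

Compound 2 stands at a limit of this assay rather than at a number, namely (the limit of > 100000 nM in this assay, at which 2 of the 3 values shown sit). Going by the values given here, the step of an at least 1.6-fold higher number from compound 1 to compound 2 (0.22 log units; that floor lies within the scatter) and the step of an at least 1.6-fold higher number from compound 1 to compound 3 (0.22 log units; that floor lies within the scatter) both start from the one compound with a proper number, and each has a floor that the scatter covers. The step that the two limits leave unreadable from compound 2 to compound 3 is unreadable between two limits. Nothing in this set is read as a change beyond the scatter.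

Compound 4 `COc1ccc(NC(=O)Cn2c(=O)c(/C=C\c3ccncc3)nc3ccccc32)cc1OC` carries the change (3,4-dimethoxyphenyl in place of 4-chlorophenyl on an amide-type nitrogen). Among the compounds with values here, no measured step touches a methoxy group; the variations among halogens on the amide aryl gave at most small floors, and the whole set sits at or close to the limit. The step of a number no higher from compound 2 to compound 4 (the limit leaves the size open) is therefore expected to be nil beyond the scatter, with a considerable chance that compound 4 again returns only a limit. Compound 4 is estimated at 100000 nM in this assay, with a range from 40000 nM to 250000 nM.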

Compound 4, half-maximal inhibitory concentration: > 100000 nM
Compound 4 was reported as a limit; the forecaster's own chance of this, stated with the estimate: 55%; the middle value lies on the limit itself.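

Working notes: the 3,4-dimethoxyphenyl group extends the amide aryl variation beyond halogens, yet compound 4 in this assay gives > 100000 nM, which is a limit and not a number. Going by these compounds alone, the only readable step is an at least 1.6-fold higher number from compound 1 to compound 4 (0.22 log units; that floor lies within the scatter), and the steps to compound 4 from compound 2 and compound 3 cannot be read, as both ends of each are limits. At this position on the amide-type nitrogen, replacing halogens with methoxy groups therefore brings no readable gain, and compound 1 remains the only one of the four compounds with a proper number, so the set is now mostly censored: the limit of > 100000 nM in this assay, at which 3 of the 4 values shown sit.

The compounds shown leave open how far compound 2, compound 3 and compound 4 lie past the limit, and so whether the chloro and methoxy substituents differ at all in this assay. They also leave open whether a different kind of group on the amide aryl, such as a dimethylamino group or a carboxylic acid, or a benzyl group in place of the aryl on the amide-type nitrogen, would give a value clearly beyond the scatter from compound 1.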